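This account rests on a few compounds, and the source may have more. Where it says the series, first, only, none or still open, it means among the compounds named here.

Measured in a functional assay on HCT-116 cells (Homo sapiens) for antiproliferative activity, read by MTT assay, with a stated time of 48 h; on this read-out lower numbers stand for stronger inhibition and higher numbers for weaker inhibition:
Compound 1 `COc1ccc(CN(C(=O)CSc2nc3ccccc3s2)c2cc(OC)c(OC)c(OC)c2)cc1O` gives 182 nM
Compound 2 `COc1ccc(CN(C(=O)CSc2nc3ccccc3s2)c2cc(OC)c(OC)c(OC)c2)cc1OC` gives 33900 nM

Of these two compounds, compound 2 has the higher number and so the weaker inhibition. Among the compounds with values here, only one measured step bears on it, a 190-fold higher number from compound 1 to compound 2 (2.27 log units; beyond the scatter), which is large and arises from a methyl in place of hydrogen on an aromatic oxygen.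

Compound 3 `COc1ccc(CN(C(=O)CSc2nc3ccccc3s2)c2cc(OC)c(OC)c(OC)c2)cc1F` has not yet been measured. It departs from compound 2 at that same part of the ring, with fluoro in place of methoxy on an aromatic carbon. The methyl that separates compound 2 from compound 1 is therefore gone again, this time along with its oxygen. Yet fluoro is not hydroxy, and no fluoro compound has a measured value to compare. The earlier step thus serves only as a partial guide. A move toward a lower number is expected in this assay, but one smaller than a 190-fold higher number from compound 1 to compound 2 (2.27 log units; beyond the scatter) and so stopping short of compound 1.

For compound 3 the estimated value is 3000 nM, with an expected range from 500 nM to 20000 nM. The expected step is an 11-fold lower number from compound 2 to compound 3 (1.05 log units; beyond the scatter).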

Compound 3, half-maximal inhibitory concentration: 1830 nM
Compound 3: middle estimate off by 1.6-fold (0.21 log units), on the high side; the measured number falls inside the stated range.
By their numbers in this assay, from the lowest: compound 1; then compound 3; then compound 2.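

In this assay, the low activity of compound 2 proves not to be a fixed feature of this place on the ring: replacing methoxy with fluoro gives a 19-fold lower number from compound 2 to compound 3 (1.27 log units; beyond the scatter), so a hydroxy group is not needed to recover much of the activity lost in compound 2, even though fluoro carries no hydrogen-bond donor. Hydroxy and fluoro are still not interchangeable here, since exchanging one for the other gives a 10-fold higher number from compound 1 to compound 3 (1.00 log units; beyond the scatter), and at this one position the three groups now rank hydroxy, then fluoro, then methoxy, from the lowest number to the highest. Nothing measured here explains this ranking.

The compounds shown leave open how a plain hydrogen, a chloro group or an amine at this place would rank against hydroxy and fluoro, and whether a longer chain such as ethoxy would raise the number as methoxy does. They also leave open whether the same ranking would hold if the methoxy group ortho to this place were exchanged for another group.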